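Swapping ethyl for cyclopropyl on the ring nitrogen

This account rests on a few compounds, and the source may have more. Where it says the series, first, only, none or still open, it means among the compounds named here.

Measured compounds:
compound 1 `CN(C)c1ncnc2c1ncn2Cc1c(F)cccc1F`: 2.2 mg/kg
compound 2 `CNc1ncnc2c1ncn2Cc1cc(F)ccc1F`: 4 mg/kg
compound 3 `CCNc1ncnc2c1ncn2Cc1ccccc1F`: 4.9 mg/kg

All three compounds share one core and were tested in a functional assay on the whole organism with Rattus norvegicus as the target, in the maximal electroshock model; a higher number here means that more compound is needed for the effect, a lower number that less compound is needed. In this assay compound 3 gives 4.9 mg/kg, and compound 2 gives 4 mg/kg, a pair of numbers that lie within the usual scatter of each other, so no order between them can be read. Compound 1 gives 2.2 mg/kg, and the gap from compound 3 to compound 1 lies beyond the scatter, so compound 1 needs less compound for the effect than compound 3 does.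

Compound 4 `Fc1ccccc1Cn1cnc2c(NC3CC3)ncnc21` has not yet been measured. It differs from compound 3 in one place: cyclopropyl in place of ethyl on a nitrogen on an aromatic ring. Cut one bond further out, the change reads ethylamino to cyclopropylamino, sitting on a nitrogen on an aromatic ring whose other neighbours are aromatic carbon.

Among the measured compounds shown here, no measured pair shows this particular change, so there is no step to lean on. The expectation is a small step, in no clear direction, likely within the scatter, as a 1.1-fold lower number from compound 3 to compound 4 (0.04 log units; within the scatter). Compound 4 is therefore estimated at 4.5 mg/kg, with a range from 2 mg/kg to 10 mg/kg.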

Compound 4, dose for half-maximal effect: 5 mg/kg
Compound 4: the middle estimate sits 1.1-fold (0.05 log units) below what was measured; measured number inside the range.
By their numbers in this assay, from the lowest: compounds 1, 2, 3 and 4 (each within the scatter of the next, the first and the last beyond it).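

In this assay, among the compounds shown here, cyclopropyl in place of ethyl on a nitrogen on an aromatic ring gives a 1.0-fold higher number from compound 3 to compound 4 (0.01 log units; within the scatter) with everything else held the same, the first comparison here that isolates one change. In this pair, closing the chain into a ring and adding one carbon leaves the dose needed for the effect indistinguishable, so this nitrogen carries either group without a readable difference. Nothing available explains why the two groups read alike.

As far as these compounds go, whether that holds for larger groups, such as a cyclobutyl ring or a longer chain like butyl, remains open. Compound 1 and compound 2 differ from compound 3 in more than one place, so their numbers cannot be assigned to the group on this nitrogen alone.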